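The source may report more compounds than this note shows. Statements on the series, on what has been measured and on what is new or still open speak of the compounds shown alone.

Compound 1, `O=C(Nc1ccc(Cl)cc1)C1CCCN(C(=O)c2cccc([N+](=O)[O-])c2)C1`, is one of two measured compounds in this set. In an ADME assay on PC-3 cells (Homo sapiens) for cytotoxicity, read by WST assay, tested at 100 uM (on this read-out higher numbers stand for more inhibition at the one concentration tested (going by the name of the read-out) and lower numbers for less inhibition), compound 1 gives 0%. For the measured compounds named here, compound 2, `CSc1cccc(C(=O)N2CCCC(C(=O)Nc3ccc(Cl)cc3)C2)c1`, in this assay gives 0%, and the single measured step, no change at the digits printed from compound 1 to compound 2 (within the scatter), came from exchanging one small group for another on an aromatic carbon. Compound 2 thus stands level with compound 1 at the digits shown, both at the floor of the scale, where no inhibition is seen at the one concentration tested. Compound 3, `COCc1cccc(C(=O)N2CCCC(C(=O)Nc3ccc(Cl)cc3)C2)c1`, has not yet been measured. It differs from compound 2 in one place: methoxymethyl in place of methylsulfanyl on an aromatic carbon. Going by the values given here, the only step that bears on this change, no change at the digits printed from compound 1 to compound 2 (within the scatter), also swapped one small group on an aromatic carbon and left the read-out unmoved. With both measured compounds at the floor, the expected step for compound 3 is no change at the digits printed from compound 2 to compound 3 (within the scatter), nothing beyond the scatter. Compound 3 is therefore estimated at 0% in this assay, with a range from -8% to 10%.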

Compound 3, a percentage reported as inhibition, at one concentration (the size of the read-out at that concentration, not a potency): 0%
Estimate against measurement, compound 3: no gap at the digits printed, and the stated range covers the measured number.
By their numbers in this assay, from the lowest: compounds 1, 2 and 3 (each within the scatter of the next).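

Methoxymethyl is a third group on this aromatic carbon, meta to a large group, and in this assay it gives no change at the digits printed from compound 2 to compound 3 (within the scatter) and no change at the digits printed from compound 1 to compound 3 (within the scatter). The position now holds a nitro group, a sulfur-linked group and an oxygen-containing chain of 3 heavy atoms, and none of the three compounds lifts the read-out off the floor of the scale, so for these compounds the exchange at this position makes no visible difference. Nothing measured here explains this flat result.

With every value at the floor, the compounds shown cannot rank these groups against one another. They leave open whether an amine, a carboxylic acid or a longer chain on this same carbon would produce any inhibition at the one concentration tested.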